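Series notes: acid to tert-butyl ester at compound 3

This account rests on a few compounds, and the source may have more. Where it says the series, first, only, none or still open, it means among the compounds named here.

Three compounds of this series have numbers in an assay on isolated protein for inhibition of cathepsin S (Homo sapiens); on this read-out lower numbers stand for stronger inhibition and higher numbers for weaker inhibition. Compound 1 `O=C(NCCNc1ccc(F)cc1)[C@H](CC1CCCCC1)Nc1nc2cc(F)ccc2o1` gives 197 nM in this assay. Compound 2 `COC(=O)c1ccc2nc(N[C@@H](CC3CCCCC3)C(=O)NCCNc3ccc(F)cc3)oc2c1` gives 43 nM in this assay. Compound 3 `O=C(O)C[C@@H](CN1CCc2cc(F)ccc21)NC(=O)[C@H](CC1CCCCC1)Nc1nc2ccc(Cl)cc2o1` gives 27 nM in this assay, the lowest of the three numbers; the gap to compound 2 lies within the scatter, so the two cannot be ordered, while the gap to compound 1 lies beyond the scatter.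

Compound 4 `CC(C)(C)OC(=O)C[C@@H](CN1CCc2cc(F)ccc21)NC(=O)[C@H](CC1CCCCC1)Nc1nc2ccc(Cl)cc2o1` has not been measured. It differs from compound 3 in one place: tert-butyl in place of hydrogen on an oxygen next to a carbonyl group. Within the data shown here, no pair of measured compounds shares this change, so there is no measured step to lean on; the three measured compounds all carry different cores and side chains, and their numbers cannot be read as a step for the acid-to-ester change.

Expectation: the step from compound 3 to compound 4 is estimated as a modest rise in this assay, a 2.2-fold higher number from compound 3 to compound 4 (0.35 log units; beyond the scatter), and the range is kept wide to allow no step beyond the scatter. Compound 4 is therefore expected to give about 60 nM in this assay, with a range from 15 nM to 250 nM.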

Compound 4, inhibition constant: 730 nM
Estimate against measurement, compound 4: 12-fold (1.09 log units) below; measured number above the stated range.
By their numbers in this assay, from the lowest: compounds 3 and 2 (each within the scatter of the next); then compound 1; then compound 4.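

Working notes on the carboxy position: in this assay, tert-butyl in place of hydrogen on an oxygen next to a carbonyl group gives a 27-fold higher number from compound 3 to compound 4 (1.43 log units; beyond the scatter) and so makes a large difference at this place. Among these compounds, this is the first step that can be read with all else held the same, since the three earlier compounds differ in core and side chain and could say nothing about this position. Within this pair, the low number belongs to the free carboxylic acid and not to its tert-butyl ester, so the carboxy group cannot be capped in this way without a large rise, but no accompanying measurement bears on the origin of the step.

This single pair does not separate the loss of the hydrogen from the entry of the tert-butyl, and a methyl ester, a primary amide or a tetrazole at the same place would help tell these two apart. As far as these compounds go, whether the same change gives a step of similar size on the cores of compound 1 or compound 2, which carry no such carboxymethyl chain, also remains open.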